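Compound 3 amide-to-benzyl switch: efficacy expectation

The source may report more compounds than this note shows. Statements on the series, on what has been measured and on what is new or still open speak of the compounds shown alone.

Compound 1 `CC(C)c1onc(-c2c(Cl)cccc2Cl)c1COc1ccc(N(C)C(=O)c2ccc(C(=O)O)cc2)c(C(F)(F)F)n1` gives 101% in an assay on isolated protein for agonist activity at Bile acid receptor (Homo sapiens), read by FRET (on this read-out higher numbers stand for larger maximal responses and lower numbers for smaller maximal responses), the higher of the two numbers seen; compound 2 `Cc1nc(OCc2c(-c3c(Cl)cccc3Cl)noc2C(C)C)ccc1N(C)C(=O)c1ccc(C(=O)O)cc1` gives 95%, and the step of a number 6 percentage points lower from compound 1 to compound 2 (within the scatter) is within the scatter. Compound 3 `CC(C)c1onc(-c2c(Cl)cccc2Cl)c1COc1ccc(N(C)Cc2ccc(CCC(=O)O)cc2)c(C(F)(F)F)n1` differs from compound 1 as follows: 4-(2-carboxyethyl)benzyl in place of (4-carboxyphenyl)carbonyl on a nitrogen on an aromatic ring. For the measured compounds named here, no measured step touches this part of the core, so the only step available, methyl for trifluoromethyl, does not bear on it and gives no direction. The expected change is a modest drop, a number 21 percentage points lower from compound 1 to compound 3 (beyond the scatter), with wide uncertainty. Compound 3 is therefore estimated at 80%, with a range from 30% to 110%.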

Compound 3, largest response reached (reported as efficacy), in percent of the reference or control that the assay uses: 96%
The estimate for compound 3 lay 16 percentage points below the measured number, within the range that was stated.
By their numbers in this assay, from the lowest: compounds 2, 3 and 1 (each within the scatter of the next).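

In this assay the exchange of (4-carboxyphenyl)carbonyl for 4-(2-carboxyethyl)benzyl on the nitrogen gives a number 5 percentage points lower from compound 1 to compound 3 (within the scatter) at this position. In this pair, the amide carbonyl is therefore not required for a maximal response within the scatter of that of compound 1, with a carboxylic acid present in both groups. No measurement available here explains this result.

The loss of the carbonyl and the longer chain arrive together in compound 3, leaving their separate contributions open. Also open, going by these compounds, is whether a tetrazole in place of the carboxylic acid would keep the response.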